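This account rests on a few compounds, and the source may have more. Where it says the series, first, only, none or still open, it means among the compounds named here.

Compound 1 `COC(=O)/C=C/c1cccc(N(Cc2ccc(-c3ccc(C(C)(C)C)cc3)cc2)C(=O)C2CCCCC2)c1` gives 132 nM in an assay on isolated protein with Bile acid receptor (Homo sapiens) as the target; on this read-out lower numbers stand for an effect already at smaller amounts and higher numbers for an effect only at larger amounts of compound. Compound 2 `CCOC(=O)/C=C/c1ccc(CN(C(=O)C2CCCCC2)c2cccc(/C=C/C(=O)OC)c2)cc1` gives only a limit in this assay, namely > 1000 nM; it stands at the limit of > 1000 nM in this assay, at which 1 of the 2 values shown sits. Going by the values given here, the one measured step, an at least 7.5-fold higher number from compound 1 to compound 2 (0.87 log units; beyond the scatter), shows how much the 2-(ethoxycarbonyl)ethenyl group costs against a 4-(tert-butyl)phenyl group. Compound 3 `COC(=O)/C=C/c1cccc(N(Cc2ccc(-c3cccc(OC(F)(F)F)c3)cc2)C(=O)C2CCCCC2)c1` undoes a change of this kind: 3-(trifluoromethoxy)phenyl in place of 2-(ethoxycarbonyl)ethenyl on an aromatic carbon. Compound 3 is therefore expected to move by an at least 4.5-fold lower number from compound 2 to compound 3 (0.65 log units; beyond the scatter), because compound 1 with its aryl group gives 132 nM. Compound 3 is estimated at 220 nM, within 80 nM to 700 nM.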

Compound 3, half-maximal effective concentration: 420 nM
For compound 3 the middle estimate is 1.9-fold (0.28 log units) below the measured one; measured number inside the range.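

In this assay, the gain from an aryl group on this aromatic carbon, para to a large group, is not confined to 4-(tert-butyl)phenyl, since 3-(trifluoromethoxy)phenyl also improves on 2-(ethoxycarbonyl)ethenyl, with an at least 2.3-fold lower number from compound 2 to compound 3 (0.37 log units; beyond the scatter). Compound 2 gives only a limit, > 1000 nM. The two aryl groups are not equivalent, however, with a 3.2-fold higher number from compound 1 to compound 3 (0.50 log units; beyond the scatter). Still open, as far as these compounds go, is how a carboxylic acid or an amine would read at this place, and how 4-(trifluoromethoxy)phenyl would compare with 3-(trifluoromethoxy)phenyl.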